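The source may hold more compounds than are shown below. What is called first, only, known or untested is meant among the compounds shown, and "the series" means these compounds.

Measured compounds:
- compound 1, `COc1cc(-c2ccnc3cc(-c4ccc(C)cc4)nn23)cc(OC)c1OC`; in a functional assay on MCF7 cells (Homo sapiens) for inhibition, read by CCK-8 assay, with a stated time of 48 h (a lower number here means a stronger inhibitor, a higher number a weaker inhibitor), compound 1 gives 47 nM
- compound 2, `COc1ccc(-c2cc3nccc(-c4cc(OC)c(OC)c(OC)c4)n3n2)cc1[N+](=O)[O-]`; in this assay compound 2 reaches only a limit of the assay, > 10000 nM
- compound 3, `COc1cc(-c2ccnc3cc(-c4ccc(-c5cnn(C)c5)cc4)nn23)cc(OC)c1OC`; in this assay compound 3 gives 274 nM

Among the two numbers shown, compound 3 carries the higher one; its nearest neighbour is compound 1, which lies lower by the step of a 5.8-fold higher number from compound 1 to compound 3 (0.77 log units; beyond the scatter). The third value shown is a limit, (the limit of > 10000 nM in this assay, at which 1 of the 3 values shown sits), and so is not a number.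

Compound 4, `COc1ccc(-c2cc3nccc(-c4cc(OC)c(OC)c(OC)c4)n3n2)cc1`, differs from compound 3 in one place: methoxy in place of 1-methyl-1H-pyrazol-4-yl on an aromatic carbon.

Among the measured compounds shown here, the only measured step that bears on this position is the one from compound 1 to compound 3, where 1-methyl-1H-pyrazol-4-yl in place of methyl raised the number by a 5.8-fold higher number from compound 1 to compound 3 (0.77 log units; beyond the scatter). Compound 4 undoes that ring and puts a methoxy where the methyl of compound 1 stood, so the number is expected to fall back toward the value of compound 1, a step of about a 3.9-fold lower number from compound 3 to compound 4 (0.59 log units; beyond the scatter). Compound 4 is therefore estimated at 70 nM, within 25 nM to 250 nM.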

Compound 4, half-maximal inhibitory concentration: 125 nM
Beside the measured number, compound 4's estimate is 1.8-fold (0.25 log units) below it; the measured number falls inside the stated range.
By their numbers in this assay, from the lowest: compound 1; then compound 4; then compound 3. At a limit, above all of these: compound 2.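

The new compound places methoxy on the same aromatic carbon that carries methyl in compound 1 and 1-methyl-1H-pyrazol-4-yl in compound 3, and in this assay it gives an order of three groups at this position rather than a single comparison: a 2.7-fold higher number from compound 1 to compound 4 (0.42 log units; beyond the scatter) and a 2.2-fold lower number from compound 3 to compound 4 (0.34 log units; beyond the scatter), so methoxy falls in the middle and methyl gives the lowest number. Compound 4 also shows how much the nitro group of compound 2 matters, since hydrogen in its place gives an at least 80-fold lower number from compound 2 to compound 4 (1.90 log units; beyond the scatter). That step starts from a limit and not a number: the limit of > 10000 nM in this assay, at which 1 of the 4 values shown sits.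

What the compounds shown leave open is how an amine or a fluorine would read in the place of the nitro group. As far as these compounds go, it also remains open whether a hydroxyl group or a longer chain such as ethoxy, in the place of the methoxy, would fit this order.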